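Replacing the phenoxy of compound 2 with a nitrile

A few compounds are considered here, and "the series" means these few. Any claim that something is new, unique, unknown or untested is made for them only; others in the source may bear on it.

Measured compounds:
compound 1 `NC(=O)c1ccc(-c2cccc(OC(=O)NC3CCCCC3)c2)cc1` gives 5910 nM
compound 2 `O=C(NC1CCCCC1)Oc1cccc(-c2cccc(Oc3ccccc3)c2)c1` gives 420 nM

In an assay on cell membranes for binding affinity to Fatty-acid amide hydrolase 1 (Rattus norvegicus) (on this read-out lower numbers stand for stronger inhibition and higher numbers for weaker inhibition), compound 2 gives 420 nM, the lowest of the two numbers on hand; compound 1 gives 5910 nM in this assay, and the gap between the two is well beyond the usual scatter. Within the data shown here, no single-change step between measured compounds exists in this set, so the comparison rests on these two values only.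

Compound 3 `N#Cc1cccc(-c2cccc(OC(=O)NC3CCCCC3)c2)c1` arises from compound 2 by cyano in place of phenoxy on an aromatic carbon, a cyano in place of phenoxy on an aromatic carbon. Among the measured compounds shown here, no measured pair shows what this exchange does in this assay. For the measured compounds named here, since the only other compound in the set, compound 1, lies far above compound 2, a move away from the phenoxy of compound 2 is expected to carry a weaker number, though of uncertain size.

For compound 3 the step of a 1.9-fold higher number from compound 2 to compound 3 (0.28 log units; within the scatter) is expected, toward a higher number. Compound 3 is thus estimated at 800 nM, with a range from 150 nM to 4000 nM.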

Compound 3, half-maximal inhibitory concentration: 33.9 nM
Estimate against measurement, compound 3: 24-fold (1.37 log units) above; the measured number lies below the stated range.
By their numbers in this assay, from the lowest: compound 3; then compound 2; then compound 1.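

The exchange of phenoxy for cyano on an aromatic carbon gives, in this assay, a 12-fold lower number from compound 2 to compound 3 (1.09 log units; beyond the scatter) and provides the only single-change comparison among the compounds shown. At this position, therefore, the phenoxy and its aromatic ring are not required for a low number, since the much smaller cyano, which has no ring, gives the lower number of the pair. The count of hydrogen-bond acceptors is the same on both sides of the exchange, so that count does not separate the two groups, and no measurement on hand accounts for the size of the step.

The compounds shown leave open whether the lower number depends on the cyano itself or comes mainly from the removal of the phenoxy, a question that a hydrogen, a fluorine, a methoxy or a carboxylic acid at the same position would help to settle. They also leave open whether the same exchange would give a step of similar size on another carbon of that ring or with a different group elsewhere on the shared core.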